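Swapping chloro for bromo in a small series

This account rests on a few compounds, and the source may have more. Where it says the series, first, only, none or still open, it means among the compounds named here.

compound 1 `O=C(CCCCC1CCSS1)Nc1ccccc1Cl` gives 7.74%
compound 2 `O=C(CCCCC1CCSS1)Nc1ccccn1` is reported as "not active" (no number reported)
compound 3 `O=C(CCCCC1CCSS1)Nc1ccc(Cl)cn1` gives 2.1%

Among the compounds with values here, these results come from a functional assay on HO8910 cells (Homo sapiens) for inhibition, read by MTT assay, with a stated time of 24 h, tested at 1 ug/mL (a lower number here means less inhibition of growth, a higher number more inhibition of growth at the concentration tested), and only two of them are numbers. Within the data shown here, in this test compound 3 gives 2.1% as its result, and that number lies within the usual scatter of the one for compound 1, so the two cannot be told apart. Compound 2 offers no number to compare.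

The next compound to be tested, compound 4 `O=C(CCCCC1CCSS1)Nc1ccc(Br)cn1`, differs from compound 3 in one place: bromo in place of chloro on an aromatic carbon, with bromo in place of chloro on an aromatic carbon. Among the measured compounds shown here, no pair of measured compounds shows this exchange, so the data give no direct guide to the size of the step. With so little to go on, no change beyond the scatter is expected in this assay, and any drift is expected to be slightly upward. Compound 3 stands at 2.1%. That number leaves little room to fall. The expected change is a number 2.9 percentage points higher from compound 3 to compound 4 (within the scatter), an estimate that stays within the scatter. For compound 4 the estimated result is 5%, with an expected range from 0% to 14% as the likely span.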

Compound 4, percent growth inhibition at one concentration: 4.27%
Compound 4: the middle estimate sits 0.7 percentage points above what was measured; the range from low to high includes it.
By their numbers in this assay, from the lowest: compounds 3, 4 and 1 (each within the scatter of the next).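

In this assay, bromo in place of chloro on an aromatic carbon, two atoms from the ring nitrogen and para to a large group, gives a number 2.2 percentage points higher from compound 3 to compound 4 (within the scatter). Within the data shown here, this is the first direct reading of this exchange at this position, and it shows that chloro and bromo cannot be told apart here, with both compounds showing little inhibition of growth at the one concentration tested. Nothing measured here bears on why the two compounds read so alike.

The compounds shown leave open whether a different group at this position, such as an amine, a methoxy group or a carboxylic acid, would move the result beyond the scatter, since a swap between two such similar single atoms explores very little. They also leave open whether bromo in place of chloro would stay within the scatter in compound 1, where the chloro sits on a different core and the exchange could give another result.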